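The source may hold more compounds than are shown below. What is called first, only, known or untested is meant among the compounds shown, and "the series" means these compounds.

In a functional assay on PC-3 cells (Homo sapiens) for cytotoxicity, with a stated time of 48 h (on this read-out lower numbers stand for stronger inhibition and higher numbers for weaker inhibition), compound 2 (`COc1cc(OC)c(C(=O)/C=C/c2ccccc2)c(OC)c1`) gives 5100 nM. For the measured compounds named here, the only other measured compound, compound 1 (`COc1cc(OC)c(C(=O)/C=C/c2ccccc2OC)c(OC)c1`), gives 8100 nM, and these two numbers lie within the scatter of each other. The unmeasured compound 3 (`COc1cc(OC)c(C(=O)/C=C/c2ccc(Cl)cc2)c(OC)c1`) has chloro in place of hydrogen on an aromatic carbon, para to a large group, which turns phenyl into 4-chlorophenyl: chloro in place of hydrogen on an aromatic carbon. Just one measured step bears on this change, hydrogen in place of methoxy on an aromatic carbon, which gives a 1.6-fold lower number from compound 1 to compound 2 (0.20 log units; within the scatter). Going by the values given here, it involves a different group, so it is only a loose guide, and no measured step involves chloro. Still, it offers no sign that a single swap of this kind matters much in this assay. No step beyond the scatter is therefore expected, and the estimated step is a 1.3-fold lower number from compound 2 to compound 3 (0.11 log units; within the scatter). For compound 3 the expected value is 4000 nM, with an estimated range from 1500 nM to 11000 nM.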

Compound 3, half-maximal inhibitory concentration: 5800 nM
The estimate for compound 3 lay 1.5-fold (0.16 log units) below the measured number; the range from low to high includes it.
By their numbers in this assay, from the lowest: compounds 2, 3 and 1 (each within the scatter of the next).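

Placing chloro in place of hydrogen on an aromatic carbon, para to a large group, gives a 1.1-fold higher number from compound 2 to compound 3 (0.06 log units; within the scatter) in this assay and so leaves no mark that can be told apart from the scatter. The wider swap, 4-chlorophenyl in place of 2-methoxyphenyl, gives a 1.4-fold lower number from compound 1 to compound 3 (0.15 log units; within the scatter) and also stays within the scatter, so neither of these two changes to this aromatic ring shifts the number by a readable amount. Nothing measured here offers an explanation for how close these numbers lie.

Chloro is the only group shown at this position, so it remains open whether an amine or a carboxylic acid on the same carbon would move the number beyond the scatter. Also open, on these data alone, is what chloro would do on the other carbons of this ring.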